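Methoxy in place of hydrogen: notes on compound 3

A few compounds are considered here, and "the series" means these few. Any claim that something is new, unique, unknown or untested is made for them only; others in the source may bear on it.

- compound 1 `Cc1ccc2c(=O)cc(/C=C/[S+](C)[O-])oc2c1`: 7000 nM
- compound 2 `C[S+]([O-])/C=C/c1cc(=O)c2ccccc2o1`: 8000 nM

Within the data shown here, in a functional assay on DLD-1 cells (Homo sapiens) for cytotoxicity, with a stated time of 48 h (on this read-out higher numbers stand for weaker inhibition and lower numbers for stronger inhibition), only two compounds have been measured so far. Compound 2 gives 8000 nM, which cannot be separated from compound 1 at 7000 nM.

The next compound is compound 3 `COc1ccc2c(=O)cc(/C=C/[S+](C)[O-])oc2c1`, reached from compound 2 by methoxy in place of hydrogen on an aromatic carbon. Among the measured compounds shown here, one measured step bears on this change: a 1.1-fold higher number from compound 1 to compound 2 (0.06 log units; within the scatter), hydrogen in place of methyl on an aromatic carbon. For the measured compounds named here, that step stays within the scatter, but it involves methyl, and no compound with methoxy has been measured. The evidence is therefore thin, and no shift beyond the scatter is expected in either direction in this assay. The expected change is a 1.1-fold lower number from compound 2 to compound 3 (0.06 log units; within the scatter). For compound 3 the estimated value is 7000 nM, with an expected range of 3000 nM to 16000 nM.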

Compound 3, half-maximal inhibitory concentration: 7800 nM
Estimate against measurement, compound 3: 1.1-fold (0.05 log units) below, and the stated range covers the measured number.
By their numbers in this assay, from the lowest: compounds 1, 3 and 2 (each within the scatter of the next).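

In this assay, methoxy in place of hydrogen on this aromatic carbon gives a 1.0-fold lower number from compound 2 to compound 3 (0.01 log units; within the scatter), and methoxy in place of methyl at the same place gives a 1.1-fold higher number from compound 1 to compound 3 (0.05 log units; within the scatter). Hydrogen, methyl and methoxy can now be compared at this one place on the shared core, and their compounds cannot be separated, so adding the oxygen of methoxy has shown no effect on the number beyond the scatter. No measurement here offers an explanation for this flat result.

On these data alone, whether another kind of group at this place, such as an amine, a carboxylic acid or a longer chain, would give a step beyond the scatter remains open. The compounds shown also leave open whether this flat response holds elsewhere on the core or with a different side chain.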